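Fluoro to Trifluoromethoxy on a Shared Pyridine-Free Core

The source may hold more compounds than are shown below. What is called first, only, known or untested is meant among the compounds shown, and "the series" means these compounds.

Compound 1, `Oc1ccc(-c2cc(-c3cccc(F)c3)cc(-c3cccc(O)c3)n2)cc1`: 3510 nM in a functional assay on T47D cells (Homo sapiens) for inhibition; on this read-out higher numbers stand for weaker inhibition and lower numbers for stronger inhibition.
Compound 2, `Oc1ccc(-c2cc(-c3cccc(F)c3)cc(-c3ccc(O)cc3)n2)cc1`: in this assay compound 2 reaches only a limit, > 50000 nM.
Compound 3, `Oc1ccc(-c2cc(-c3ccc(C(F)(F)F)cc3)cc(-c3cccc(O)c3)n2)cc1`: 2870 nM in this assay.

Compound 1 stands highest of the two numbers given, with compound 3 nearest; the third value is a limit. Compound 4, `Oc1ccc(-c2cc(-c3cccc(OC(F)(F)F)c3)cc(-c3cccc(O)c3)n2)cc1`, differs from compound 1 by trifluoromethoxy in place of fluoro on an aromatic carbon. Within the data shown here, no measured step swaps these exact groups. The step that touches the same ring, 4-(trifluoromethyl)phenyl in place of 3-fluorophenyl, gave a 1.2-fold lower number from compound 1 to compound 3 (0.09 log units; within the scatter). The large step of an at least 14-fold higher number from compound 1 to compound 2 (1.15 log units; beyond the scatter) concerns the hydroxyphenyl and does not bear on this change. On that basis no step beyond the scatter is expected in this assay. Compound 4 is therefore estimated at 3200 nM, with a range from 1200 nM to 9000 nM. Compound 4 is thus expected to show a 1.1-fold lower number from compound 1 to compound 4 (0.04 log units; within the scatter).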

Compound 4, half-maximal inhibitory concentration: 5040 nM
Estimate against measurement, compound 4: 1.6-fold (0.20 log units) below, within the range that was stated.
By their numbers in this assay, from the lowest: compounds 3, 1 and 4 (each within the scatter of the next). At a limit, above all of these: compound 2.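

In this assay, trifluoromethoxy in place of fluoro gives a 1.4-fold higher number from compound 1 to compound 4 (0.16 log units; within the scatter), so this position, meta to a large group, takes the larger group of 5 heavy atoms without a step beyond the scatter. Unlike the earlier change to 4-(trifluoromethyl)phenyl, this step keeps the substituent at the same place on the ring. Nothing given here bears on the cause of this result. The compounds shown carry only fluorinated groups on this ring, and whether an amine or a carboxylic acid at this place would also stay within the scatter remains open.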